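Swapping the aryl amide of a urotensin receptor ligand

The source may hold more compounds than are shown below. What is called first, only, known or untested is meant among the compounds shown, and "the series" means these compounds.

Measured compounds:
compound 1, `COc1ccc(C(=O)NC(CCN(C)C)c2ccc(Cl)cc2)cc1`, 1350 nM
compound 2, `CN(C)CCC(NC(=O)c1ccc(C(F)(F)F)cc1)c1ccc(Cl)cc1`, 77.6 nM

Both compounds share the same core and differ only in the group on the carbonyl carbon of the amide. In an assay on NIH3T3 cells with Urotensin-2 receptor (Homo sapiens) as the target (on this read-out higher numbers stand for an effect only at larger amounts of compound and lower numbers for an effect already at smaller amounts), compound 1 gives 1350 nM, the highest of the two numbers, while compound 2 gives 77.6 nM. Among the measured compounds shown here, the one measured step, a 17-fold lower number from compound 1 to compound 2 (1.24 log units; beyond the scatter), shows that exchanging the substituent on that aromatic ring can move the number a long way.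

Compound 3, `Cc1cccc(Cl)c1C(=O)NC(CCN(C)C)c1ccc(Cl)cc1`, is not yet measured. It differs from compound 1 by 2-chloro-6-methylphenyl in place of 4-methoxyphenyl on a carbonyl carbon. For the measured compounds named here, no measured step describes this exact exchange; the step from compound 1 to compound 2 only suggests that the group at this position matters. A modest improvement is therefore expected in this assay, with wide uncertainty. For compound 3 the estimate is 600 nM, within 120 nM to 3000 nM, a step of a 2.3-fold lower number from compound 1 to compound 3 (0.35 log units; beyond the scatter).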

Compound 3, half-maximal effective concentration: 5130 nM
The estimate for compound 3 lay 8.6-fold (0.93 log units) below the measured number; measured number above the stated range.
By their numbers in this assay, from the lowest: compound 2; then compound 1; then compound 3.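

In this assay, 2-chloro-6-methylphenyl in place of 4-methoxyphenyl on the carbonyl carbon gives a 3.8-fold higher number from compound 1 to compound 3 (0.58 log units; beyond the scatter). The group at this position can therefore raise the number as well as lower it, whereas the earlier step showed only a fall. The two exchanged groups have the same heavy-atom count, so that count alone does not hold the number steady here, and no measurement at hand explains the rise.

The compounds shown leave open whether the chlorine or the methyl alone would give a similar rise, as the two appear only together in this group. Also open, as far as these compounds go, is how the number would respond to a cyclohexyl group on the carbonyl carbon, or to a phenyl ring carrying a nitrile.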